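The source may hold more compounds than are shown below. What is called first, only, known or untested is meant among the compounds shown, and "the series" means these compounds.

Compound 1 `Cn1ncc2c(=O)n(-c3ccccc3)c(SC(C)(C)c3ccccc3)nc21` and compound 2 `O=c1c2cncn2nc(SCc2cccc(F)c2)n1-c1ccccc1` share one core and differ only in the group carried on the sulfur. In an assay on isolated protein for inhibition of aldehyde dehydrogenase 1A1 (Homo sapiens) (a higher number here means a weaker inhibitor, a lower number a stronger inhibitor), compound 1 gives 1900 nM, the lowest of the two numbers, while compound 2 gives 2200 nM, a gap that sits within the usual scatter. Compound 3 `CC(Sc1nc2c(cnn2C)c(=O)n1-c1ccccc1)c1cncnc1` has not yet been measured in this assay. It differs from compound 1 in one place: 1-(pyrimidin-5-yl)ethyl in place of 1-methyl-1-phenylethyl on a sulfur. Among the compounds with values here, no measured pair shows a change of this kind, so the expected step is only a modest one, in either direction or none beyond the scatter, estimated as a 1.6-fold higher number from compound 1 to compound 3 (0.20 log units; within the scatter). Compound 3 is therefore expected to give about 3000 nM, within a range from 1000 nM to 10000 nM.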

Compound 3, half-maximal inhibitory concentration: 94 nM
Estimate against measurement, compound 3: 32-fold (1.50 log units) above; the measured number lies below the stated range.
By their numbers in this assay, from the lowest: compound 3; then compounds 1 and 2 (each within the scatter of the next).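

In this assay, the group on the sulfur proves to be a powerful handle on this core, with a step of a 20-fold lower number from compound 1 to compound 3 (1.31 log units; beyond the scatter). The swap changes two things at once: the ring gains 2 hetero atoms, and the carbon bearing the ring loses a methyl. No measurement here explains why the number falls. On these data alone, the share of each change therefore stays open. A 1-phenylethyl group on the sulfur would help separate them, by keeping the carbon-only ring while removing that methyl.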